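The source may hold more compounds than are shown below. What is called first, only, known or untested is meant among the compounds shown, and "the series" means these compounds.

Values in a functional assay on HCT-116 cells (Homo sapiens) for antiproliferative activity, read by CellTiter-Glo, with a stated time of 72 h; a higher number here means a weaker inhibitor, a lower number a stronger inhibitor:
- Compound 1 `COc1ccccc1-c1cc(/C=C/c2ccc(C(=O)NO)cc2)ccn1`: 8440 nM
- Compound 2 `O=C(NO)c1ccc(/C=C/c2ccnc(-c3ccc(F)cc3)c2)cc1`: > 10000 nM, a limit of the assay and not a number
- Compound 3 `COc1ccc(-c2cc(/C=C/c3ccc(C(=O)NO)cc3)ccn2)cc1`: 3560 nM

Compound 3 stands lowest of the three, with a 2.4-fold lower number from compound 1 to compound 3 (0.37 log units; beyond the scatter) and an at least 2.8-fold lower number from compound 2 to compound 3 (0.44 log units; beyond the scatter).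

Compound 4 `O=C(NO)c1ccc(/C=C/c2ccncc2)cc1` carries hydrogen in place of 4-methoxyphenyl on an aromatic carbon.

Among the compounds with values here, those two steps only exchange one substituted phenyl for another, and no measured step removes the group. They therefore give only a loose guide to size. No clear shift in either direction is expected, though the uncertainty is wide. The expected step is a 1.4-fold higher number from compound 3 to compound 4 (0.15 log units; within the scatter). For compound 4 the estimate is 5000 nM, with an expected range of 1200 nM to 20000 nM.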

Compound 4, half-maximal inhibitory concentration: 3910 nM
Beside the measured number, compound 4's estimate is 1.3-fold (0.11 log units) above it; the measured number falls inside the stated range.
By their numbers in this assay, from the lowest: compounds 3 and 4 (each within the scatter of the next); then compound 1. At a limit, above all of these: compound 2.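

In this assay, within the data shown here, the first step that removes the group shows that the 4-methoxyphenyl next to the ring nitrogen can give way to hydrogen with no shift beyond the scatter: a 1.1-fold higher number from compound 3 to compound 4 (0.04 log units; within the scatter). Hydrogen in place of 2-methoxyphenyl gives a 2.2-fold lower number from compound 1 to compound 4 (0.33 log units; beyond the scatter), so this substituted phenyl compares unfavourably with no group at all. Hydrogen in place of 4-fluorophenyl gives an at least 2.5-fold lower number from compound 2 to compound 4 (0.40 log units; beyond the scatter), only a floor, as compound 2 carries a limit and not a number: the limit of > 10000 nM in this assay, at which 1 of the 4 values shown sits.

Open, going by these compounds, is whether a small group at this position, such as an amine or a methyl, would move the number beyond the scatter from compound 4.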